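A few compounds are considered here, and "the series" means these few. Any claim that something is new, unique, unknown or untested is made for them only; others in the source may bear on it.

In an ADME assay on HEK293 cells (Homo sapiens) for cytotoxicity, read by resazurin assay, with a stated time of 16 h (on this read-out higher numbers stand for an effect only at larger amounts of compound and lower numbers for an effect already at smaller amounts), compound 2 `COc1cc(/C=C/C(=O)CC(=O)/C=C/c2ccc(OC(C)=O)c(OC)c2)ccc1OC(C)=O` gives 80000 nM. In the same test compound 3 `COc1cc(/C=C/C(=O)CC(=O)/C=C/c2ccc(OC(C)=O)cc2)ccc1OC(C)=O` gives 49000 nM, which lies within the scatter of compound 2, so these two numbers cannot be told apart. Compound 1 `COc1cc(/C=C/C(=O)CC(=O)/C=C/c2ccc(OCC=C(C)C)c(OC)c2)ccc1O` is reported only as a limit, > 500000 nM. Compound 3 therefore stands level with compound 2, and it has a real number to compare against only there.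

The next compound, compound 4 `CC(=O)Oc1ccc(/C=C/C(=O)CC(=O)/C=C/c2ccc(OC(C)=O)c(O)c2)cc1`, keeps the shared core but changes one group: hydrogen in place of methyl on an oxygen on an aromatic ring. In words, this is hydrogen in place of methyl on an oxygen on an aromatic ring, so methoxy becomes hydroxy.

Going by the values given here, only one measured step bears on this change: a 1.6-fold lower number from compound 2 to compound 3 (0.21 log units; within the scatter). There, hydrogen takes the place of methoxy on an aromatic carbon. It is not the same change, but it also alters a methoxy, and it stays within the scatter. With this single small step as the guide, no clear shift is expected in this assay. The expected step is a 1.1-fold lower number from compound 3 to compound 4 (0.04 log units; within the scatter), which would stay within the usual scatter. The estimated value for compound 4 is 45000 nM, with the measurement expected to fall between 16000 nM and 130000 nM.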

Compound 4, half-maximal effective concentration: > 500000 nM
Compound 4: a limit, no number; the forecaster's own chance of this, stated with the estimate: 8%; middle value at least 11-fold (1.04 log units) away from the limit.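

In this assay, hydrogen in place of methyl on an oxygen on an aromatic ring gives an at least 10-fold higher number from compound 3 to compound 4 (1.00 log units; beyond the scatter), so this small change, methoxy to hydroxy, clearly moves the read-out. Going by these compounds alone, the only earlier step, a 1.6-fold lower number from compound 2 to compound 3 (0.21 log units; within the scatter), replaced a whole methoxy with hydrogen on an aromatic carbon and did not do so, which shows that the loss of a single methyl can matter more here than that step suggested. From the compounds shown here alone, the full size of the new step stays unknown because the value of compound 4 is only a limit and not a number: the limit of > 500000 nM in this assay, at which 2 of the 4 values shown sit.

Going by these compounds, whether another group on this oxygen, such as an ethyl or a longer chain, would behave like the methoxy or like the hydroxy remains open, as does the effect of an amine in place of the hydroxy. It is also open whether methoxy to hydroxy gives a similar step in other compounds with the shared core, as this pair is the only example shown.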